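A few compounds are considered here, and "the series" means these few. Any claim that something is new, unique, unknown or untested is made for them only; others in the source may bear on it.

Measured so far:
compound 1, `CCS(=O)(=O)Nc1cc(C2CCCCC2)cc2c1CCCC2c1c[nH]cn1`: 891 nM
compound 2, `CCCS(=O)(=O)Nc1cccc2c1CCCC2c1c[nH]cn1`: < 10000 nM

In an assay on isolated protein (Cricetulus griseus) for binding affinity to Alpha-1B adrenergic receptor (Mesocricetus auratus), read by radioligand binding (a higher number here means a weaker inhibitor, a lower number a stronger inhibitor), compound 1 gives 891 nM. For compound 2 the reading in this assay is a limit of the assay, < 10000 nM, not a number. Compound 2 therefore stands at the limit of < 10000 nM in this assay, at which 1 of the 2 values shown sits, and its true place on the scale is open.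

Compound 3, `Nc1cccc2c1CCCC2c1c[nH]cn1`, is not yet measured. It differs from compound 2 in one place: hydrogen in place of propylsulfonyl on a nitrogen on an aromatic ring. For the measured compounds named here, no measured pair shows what this change does, so the expected size of the step rests on the position of compound 2 alone. Compound 3 is expected to stay at or past the limit, so the step of an at least 1.5-fold higher number from compound 2 to compound 3 (0.17 log units; that floor lies within the scatter) is expected to be small and, if anything, toward weaker binding. Compound 3 is thus estimated at 15000 nM, within a range from 3000 nM to 60000 nM.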

Compound 3, inhibition constant: 525 nM
Compound 3: middle estimate off by 29-fold (1.46 log units), on the high side; the measured number lies below the stated range.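

For the compounds shown here, compound 2 carries only a limit of the assay, not a number, so no step from compound 2 to compound 3 can be read: the limit of < 10000 nM in this assay, at which 1 of the 3 values shown sits.

The compounds shown leave open how large the change from (propylsulfonyl)amino to amino is in this assay.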